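The compounds below may be only part of what the source reports. "The series", "measured", "known", "first", "only" and "open" are said of these compounds alone.

Compound 2, `CN(C)CCCCn1c2c(c3ccccc31)C(=O)c1c[n+]([O-])c3ccccc3c1C2=O`, carries a dimethylamino group on a saturated chain attached to an aromatic nitrogen of the shared core. In a functional assay on SH-SY5Y cells (Homo sapiens) for cytotoxicity, read by MTT assay, with a stated time of 72 h (on this read-out higher numbers stand for weaker inhibition and lower numbers for stronger inhibition), compound 2 gives 250 nM, the lowest of the two numbers obtained. Compound 3, `O=C1c2c[n+]([O-])c3ccccc3c2C(=O)c2c1c1ccccc1n2Cc1cn([C@@H]2O[C@H](CO)[C@@H](O)[C@H](O)[C@H]2O)nn1`, with a different substituent on the aromatic nitrogen, gives 880 nM in this assay, a higher number than compound 2 by a margin beyond the scatter. Compound 1, `CC1(C)O[C@@H](CO)[C@H](Cn2cc(Cn3c4c(c5ccccc53)C(=O)c3c[n+]([O-])c5ccccc5c3C4=O)nn2)O1`, is reported in this assay only as a limit of > 1000 nM, not as a number. Within the data shown here, the single step between measured compounds differing in one place, an at least 1.1-fold lower number from compound 1 to compound 3 (0.05 log units; that floor lies within the scatter), rests on the limit of > 1000 nM in this assay, at which 1 of the 3 values shown sits, and therefore tells little about size.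

Compound 4, `O=C1c2c[n+]([O-])c3ccccc3c2C(=O)c2c1c1ccccc1n2CCCCn1ccnc1`, differs from compound 2 by 1H-imidazol-1-yl in place of dimethylamino on a saturated chain carbon, four bonds along the chain from an aromatic nitrogen. Among the measured compounds shown here, no measured step alters a dimethylamino group: the step from compound 1 to compound 3 changes the group on the aromatic nitrogen itself, so it does not bear on this change. With nothing to anchor a direction, a modest step either way, or none beyond the scatter, is plausible. Compound 4 is therefore expected to give about 400 nM in this assay, between 150 nM and 1200 nM, an estimated 1.6-fold higher number from compound 2 to compound 4 (0.20 log units; within the scatter).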

Compound 4, half-maximal inhibitory concentration: 130 nM
Compound 4: the middle estimate sits 3.1-fold (0.49 log units) above what was measured, and the stated range ends above it.
By their numbers in this assay, from the lowest: compounds 4 and 2 (each within the scatter of the next); then compound 3. At a limit, above all of these: compound 1.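

In this assay, among these compounds, the step to 1H-imidazol-1-yl in place of dimethylamino, on a saturated chain carbon, four bonds along the chain from an aromatic nitrogen, reads a 1.9-fold lower number from compound 2 to compound 4 (0.28 log units; within the scatter) and is the first measured change at this position. That step stays within the usual scatter, so the two groups cannot be told apart here: at this end of the chain, a small open group and a five-membered aromatic ring give numbers that repeated measurements alone could separate by as much. Nothing given here explains why the two groups read alike, and no measured property of either group is available to draw on.

On these data alone, whether a different group at this chain end, such as a morpholine ring, a primary amine or a carboxylic acid, would move the number beyond the scatter remains open. So does the part played by the chain itself, since a shorter chain or a longer chain carrying the same dimethylamino or 1H-imidazol-1-yl could read differently in this assay.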